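The compounds below may be only part of what the source reports. "The series", "measured", "known", "first", "only" and "open" are said of these compounds alone.

In an ADME assay on MRC5 cells (Homo sapiens) for cytotoxicity, read by MTT assay, with a stated time of 72 h (a lower number here means that less compound is tolerated, a higher number that more compound is tolerated), compound 1 `OC[C@H]1O[C@@H](n2cc(F)c3c(-c4cccs4)ncnc32)[C@H](O)[C@@H]1O` gives 47200 nM as a measured number. Compound 2 `OC[C@H]1O[C@@H](n2cc(Cl)c3c(-c4ccc(F)cc4)ncnc32)[C@H](O)[C@@H]1O` reads > 50000 nM as a limit only. Compound 3 `OC[C@H]1O[C@@H](n2cc(Cl)c3c(-c4ccco4)ncnc32)[C@H](O)[C@@H]1O` reads > 50000 nM as a limit only. Compound 3 thus stands at the limit of > 50000 nM in this assay, at which 2 of the 3 values shown sit, for now. The change to compound 4 `OC[C@H]1O[C@@H](n2cc(Cl)c3c(-c4cccs4)ncnc32)[C@H](O)[C@@H]1O` is thiophen-2-yl in place of furan-2-yl on an aromatic carbon on the shared core, thiophen-2-yl in place of furan-2-yl on an aromatic carbon. Within the data shown here, the only measured step at this place is a step that the two limits leave unreadable from compound 2 to compound 3 and it offers no size. Compound 1 carries the same thiophen-2-yl and gives 47200 nM as its number, so no step beyond the scatter is expected in this assay for this change. The expected step is an at least 1.0-fold lower number from compound 3 to compound 4 (0.01 log units; that floor lies within the scatter) as a working figure. Compound 4 is estimated at 48000 nM with 25000 nM to 70000 nM as its range.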

Compound 4, half-maximal cytotoxic concentration: > 50000 nM
Compound 4 ended at the assay's limit; the forecaster's own chance of this, stated with the estimate: 60%; at least 1.0-fold (0.01 log units) between middle value and limit.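

In this assay, thiophen-2-yl in place of furan-2-yl leaves compound 4 at a limit, as compound 3 and compound 2 are, so the steps among these three cannot be read. Among these compounds, the one step with a floor, chloro in place of fluoro on an aromatic carbon with thiophen-2-yl kept, is an at least 1.0-fold higher number from compound 1 to compound 4 (0.02 log units; that floor lies within the scatter). With furan-2-yl, thiophen-2-yl and 4-fluorophenyl, this place is bounded from one side only: the limit of > 50000 nM in this assay, at which 3 of the 4 values shown sit.

As far as these compounds go, how far compound 2, compound 3 and compound 4 differ from one another stays open. Also open, from the compounds shown here alone, is whether an amine or a carboxylic acid at this place would give a measured number.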